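A few compounds are considered here, and "the series" means these few. Any claim that something is new, unique, unknown or untested is made for them only; others in the source may bear on it.

Measured in a functional assay on MDA-MB-231 cells (Homo sapiens) for antiproliferative activity, read by MTT assay, with a stated time of 48 h; on this read-out lower numbers stand for stronger inhibition and higher numbers for weaker inhibition:
- Compound 1 `COc1cc(/C=N/c2c(C#N)ncn2-c2ccc(F)cc2)ccc1O`: 13600 nM
- Compound 2 `N#Cc1ncn(-c2ccc(F)cc2)c1/N=C/c1ccc(O)cc1`: 16300 nM

Only these two compounds have been measured, and compound 2, at 16300 nM, lies within the scatter of compound 1. The next compound is compound 3 `CC(C)c1ccc(/C=N/c2c(C#N)ncn2-c2ccc(F)cc2)cc1`, which keeps the shared core but has isopropyl in place of hydroxy on an aromatic carbon.

Among the compounds with values here, only one measured step bears on this change, and only indirectly. It is a 1.2-fold higher number from compound 1 to compound 2 (0.08 log units; within the scatter), where hydrogen replaces methoxy and the size of the step stays within the scatter. Within the data shown here, both measured compounds carry the hydroxy group, so no measured step shows what happens when it is removed. The data therefore give no direction for this assay, and no step beyond the scatter is expected, though the uncertainty is wide. The estimated change is a 1.1-fold lower number from compound 2 to compound 3 (0.04 log units; within the scatter). The expected value for compound 3 is 15000 nM, with an estimated range from 5000 nM to 45000 nM.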

Compound 3, half-maximal inhibitory concentration: 20500 nM
Compound 3: the middle estimate sits 1.4-fold (0.14 log units) below what was measured; the measured number falls inside the stated range.
By their numbers in this assay, from the lowest: compounds 1, 2 and 3 (each within the scatter of the next).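

In this assay, the change from hydroxy to isopropyl on an aromatic carbon, para to a large group, gives a 1.3-fold higher number from compound 2 to compound 3 (0.10 log units; within the scatter). Within the data shown here, this is the first measured step at this position in which hydroxy leaves, and it shows that a group of 1 heavy atom with 1 hydrogen-bond donor and 1 hydrogen-bond acceptor can give way to one of 3 heavy atoms with neither, without a step beyond the scatter. No measurement is at hand that would explain this result.

The compounds shown leave open whether an amine, a carboxylic acid or a longer chain at this position would give a step beyond the scatter in this assay. They also leave open how the number would respond to a change elsewhere on the shared core, since every step shown lies at this one position and stays within the scatter.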